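A few compounds are considered here, and "the series" means these few. Any claim that something is new, unique, unknown or untested is made for them only; others in the source may bear on it.

Compound 1, `COc1cc2ncnc(N3CCc4ccccc43)c2cc1NC(=O)/C=C/CN1CCCC1`, is the reference point of this small set. In a functional assay on PC-3 cells (Homo sapiens) for antiproliferative activity, read by MTT assay, with a stated time of 72 h (on this read-out lower numbers stand for stronger inhibition and higher numbers for weaker inhibition), compound 1 gives 2620 nM. Compound 2, `COc1cc2ncnc(N3CCc4ccccc43)c2cc1NC(=O)/C=C/CN1CCCCC1`, carries one change against compound 1, (piperidin-1-yl in place of pyrrolidin-1-yl on a saturated chain carbon bound to a double-bonded chain carbon), and in this assay compound 2 gives 4180 nM. The step is a 1.6-fold higher number from compound 1 to compound 2 (0.20 log units; within the scatter), so the two numbers cannot be told apart with confidence.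

Compound 3, `O=C(/C=C/CN1CCCC1)Nc1cc2c(N3CCCc4ccccc43)ncnc2cc1O[C@@H]1CCOC1`, has a different core from compound 1; the difference between the two cores is not broken down here. In this assay compound 3 gives 5780 nM, the highest of the three numbers, within the scatter of compound 2 and beyond it only against compound 1.

Compound 4, `O=C(/C=C/CN1CCCCC1)Nc1cc2c(N3CCCc4ccccc43)ncnc2cc1O[C@@H]1CCOC1`, has not yet been measured. Against compound 3 it carries piperidin-1-yl in place of pyrrolidin-1-yl on a saturated chain carbon bound to a double-bonded chain carbon, the same change that separates compound 2 from compound 1, at the same place. For the measured compounds named here, with only that one earlier pair to go on, the expected step from compound 3 to compound 4 is taken to match it, a 1.5-fold higher number from compound 3 to compound 4 (0.17 log units; within the scatter), because the earlier pair showed a 1.6-fold higher number from compound 1 to compound 2 (0.20 log units; within the scatter) and nothing in the set indicates a different outcome on the core of compound 3. On that basis compound 4 is estimated to give 8500 nM in this assay, with a plausible range from 4500 nM to 16000 nM.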

Compound 4, half-maximal inhibitory concentration: 3630 nM
For compound 4 the middle estimate is 2.3-fold (0.37 log units) above the measured one, and the stated range ends above it.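

In this assay, placing piperidin-1-yl in place of pyrrolidin-1-yl on the core of compound 3 gives a 1.6-fold lower number from compound 3 to compound 4 (0.20 log units; within the scatter), so compound 3 and compound 4 cannot be told apart with confidence. Set beside the earlier pair, the two steps run in opposite directions as printed, yet the gap between them is no larger than two such steps can show by scatter alone: the same change on two cores in this assay, a 1.6-fold higher number (0.20 log units; within the scatter) from compound 1 to compound 2 and a 1.6-fold lower number (0.20 log units; within the scatter) from compound 3 to compound 4, 2.5-fold (0.40 log units) apart, within the scatter of two such steps. This shows that on both cores the change leaves the number within the scatter, and that nothing here separates its outcome on one core from its outcome on the other; it does not show that the change has the same effect on both cores, and two pairs, neither of them resolved, say nothing about any further core.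

As far as these compounds go, what remains open is whether a different amine on the saturated chain carbon bound to a double-bonded chain carbon, such as morpholin-4-yl, 4-methylpiperazin-1-yl or an open-chain dimethylamino group, would give a step beyond the scatter on either core. Also open is whether any such group would bring the numbers of this series apart more clearly than the two saturated rings shown here.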